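Series notes: amine swap on the propoxy chain

The source may report more compounds than this note shows. Statements on the series, on what has been measured and on what is new or still open speak of the compounds shown alone.

Measured so far:
compound 1 `COc1cc2c(Oc3ccc(NC(=O)c4nn(-c5ccccc5)c(=O)cc4C)cc3F)ccnc2cc1OCCCN1CCCC1` gives 220 nM
compound 2 `COc1cc2c(Oc3ccc(NC(=O)c4nn(-c5ccccc5C(F)(F)F)c(=O)cc4C)cc3F)ccnc2cc1OCCCN1CCC(C)CC1` gives 180 nM
compound 3 `COc1cc2c(Oc3ccc(NC(=O)c4nn(-c5ccccc5OC(F)(F)F)c(=O)cc4C)cc3F)ccnc2cc1OCCCN1CCCC1` gives 180 nM

All three values come from a functional assay on HT-29 cells (Homo sapiens) for inhibition, read by MTT assay, with a stated time of 72 h; a higher number here means a weaker inhibitor, a lower number a stronger inhibitor. Compound 3 stands level with compound 2 at the digits shown, and the two together give the lowest numbers of the three, while compound 1 lies only a little higher; every gap among them is within the scatter, so no ordering can be read from them.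

Among the measured compounds shown here, the one step that can be isolated, a 1.2-fold lower number from compound 1 to compound 3 (0.09 log units; within the scatter), is within the scatter.

Compound 4 `COc1cc2c(Oc3ccc(NC(=O)c4nn(-c5ccccc5OC(F)(F)F)c(=O)cc4C)cc3F)ccnc2cc1OCCCN1CCC(C)CC1` differs from compound 3 by 4-methylpiperidin-1-yl in place of pyrrolidin-1-yl on a saturated chain carbon, three bonds along the chain from an oxygen on an aromatic ring. For the measured compounds named here, no measured step isolates this change: compound 1 and compound 2 differ at both this position and the aryl substituent, and their values in this assay lie within the scatter of each other, which is all those two numbers show. Going by the values given here, with no step bearing directly on the change, and the only measured step within the scatter, no change beyond the scatter is expected for compound 4.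

Compound 4 is therefore estimated at 180 nM, with a range of 90 nM to 360 nM, meaning an expected step of no change at the digits printed from compound 3 to compound 4 (within the scatter).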

Compound 4, half-maximal inhibitory concentration: 250 nM
For compound 4 the middle estimate is 1.4-fold (0.14 log units) below the measured one, and the stated range covers the measured number.
By their numbers in this assay, from the lowest: compounds 2, 3, 1 and 4 (each within the scatter of the next).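

In this assay, the change from 3-(pyrrolidin-1-yl)propyl to 3-(4-methylpiperidin-1-yl)propyl can now be read on its own, with the rest of the structure held fixed: a 1.4-fold higher number from compound 3 to compound 4 (0.14 log units; within the scatter). This position therefore accepts the six-membered ring in place of the five-membered ring with no shift that can be told from scatter, and with 4-methylpiperidin-1-yl held fixed, the aryl change trifluoromethoxy in place of trifluoromethyl gives a 1.4-fold higher number from compound 2 to compound 4 (0.14 log units; within the scatter), so those two substituents cannot be separated here either. Nothing available bears on the reason for these results.

Still open, on these data alone, is whether a morpholin-4-yl or dimethylamino group, or a longer chain between the oxygen and the amine, would move the number beyond the scatter. Also open, as far as these compounds go, is whether a carboxylic acid on the amine ring would do so.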